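A few compounds are considered here, and "the series" means these few. Any claim that something is new, unique, unknown or untested is made for them only; others in the source may bear on it.

In a functional assay on SF-268 cells (Homo sapiens) for inhibition, read by sulforhodamine B assay, with a stated time of 48 h (on this read-out lower numbers stand for stronger inhibition of growth and higher numbers for weaker inhibition of growth), compound 2 `COc1ccc(C2([C@H]3C[C@H](n4cc(C)c(=O)[nH]c4=O)O[C@@H]3CO[Si](C)(C)C(C)(C)C)SCCCS2)cc1OC` gives 6460 nM. Among the compounds with values here, for compound 1 `Cc1cn([C@H]2C[C@H](CC3=CC(=O)C(=O)C=C3)[C@@H](CO[Si](C)(C)C(C)(C)C)O2)c(=O)[nH]c1=O` the entry reads no result reported, so the value of compound 2 is the only number available and compound 2 cannot yet be ranked against anything. Compound 3 `COc1ccc(C2([C@H]3C[C@@H](n4cc(C)c(=O)[nH]c4=O)O[C@@H]3CO[Si](C)(C)C(C)(C)C)SCCCS2)cc1OC` has the same atoms and bonds as compound 2: the two compounds have the same atoms and bonds and differ only in configuration as drawn: 1 of 3 stereo elements differ; a stereocentre at a saturated ring carbon is drawn R in compound 2 and S in compound 3. Within the data shown here, the only change is in the configuration as drawn, where a stereocentre at a saturated ring carbon is drawn R in compound 2 and S in compound 3. Among the measured compounds shown here, no measured pair here shows what such a change does in this assay, so the expectation rests on compound 2 alone and stays uncertain. A small shift toward weaker inhibition of growth is expected, quite possibly no larger than the usual scatter. The expected change is a 1.2-fold higher number from compound 2 to compound 3 (0.09 log units; within the scatter). For compound 3 the estimated value is 8000 nM, with an expected range of 3000 nM to 25000 nM.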

Compound 3, concentration for 50% growth inhibition: 12900 nM
Beside the measured number, compound 3's estimate is 1.6-fold (0.21 log units) below it; measured number inside the range.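

Within the data shown here, this is the first measured pair in the set, and it tests a single change: inverting one stereocentre at a saturated ring carbon. In this assay the step is a 2.0-fold higher number from compound 2 to compound 3 (0.30 log units; within the scatter), so the two configurations at this position cannot be told apart here. Any real gap between the two compounds could come from only one source: the fact that compounds 2 and 3 differ only in the configuration as drawn

The pair speaks for this one stereocentre only, with everything else in the structure held the same, and leaves open whether the other two stereo elements matter in this assay. It also leaves open whether inverting this stereocentre would give a similar step in a compound carrying a free hydroxyl group or an amine in place of the silyl ether.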